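Aryl swap at the aminopyrazolopyridine core: methyl to chloro

The source may report more compounds than this note shows. Statements on the series, on what has been measured and on what is new or still open speak of the compounds shown alone.

Measured so far:
compound 1 `N#Cc1c(-c2ccco2)nc2c(c(-c3ccccc3)nn2-c2ccccc2)c1-c1ccc(O)cc1`: 4200 nM
compound 2 `COc1ccc(-c2nc3c(c(-c4ccccc4)nn3-c3ccccc3)c(-c3ccc(O)cc3)c2C#N)cc1`: 2100 nM
compound 3 `Cc1ccc(-c2nc3c(c(-c4ccccc4)nn3-c3ccccc3)c(-c3ccc(O)cc3)c2C#N)cc1`: 8800 nM

In a functional assay on K562 cells (Homo sapiens) for antiproliferative activity, read by resazurin assay, with a stated time of 72 h (on this read-out lower numbers stand for stronger inhibition and higher numbers for weaker inhibition), compound 3 carries the highest of the three numbers; a 2.1-fold higher number from compound 1 to compound 3 (0.32 log units; beyond the scatter) and a 4.2-fold higher number from compound 2 to compound 3 (0.62 log units; beyond the scatter) both go beyond the scatter, while a 2.0-fold lower number from compound 1 to compound 2 (0.30 log units; within the scatter) does not. Compound 4 `N#Cc1c(-c2ccc(Cl)cc2)nc2c(c(-c3ccccc3)nn2-c2ccccc2)c1-c1ccc(O)cc1` differs from compound 3 by chloro in place of methyl on an aromatic carbon. Within the data shown here, no measured step replaces methyl by chloro, so the bearing of the known steps is indirect: the exchange of methoxy for methyl moved the number up, and the exchange of furan-2-yl for an aryl bearing a substituent moved it either way by a modest amount. A modest change toward a lower number is therefore expected for compound 4, a 1.8-fold lower number from compound 3 to compound 4 (0.25 log units; within the scatter), with wide uncertainty. The estimated value for compound 4 in this assay is 5000 nM, with a range from 2000 nM to 13000 nM.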

Compound 4, half-maximal inhibitory concentration: 20800 nM
Compound 4: the middle estimate sits 4.2-fold (0.62 log units) below what was measured; measured number above the stated range.
By their numbers in this assay, from the lowest: compounds 2 and 1 (each within the scatter of the next); then compound 3; then compound 4.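

In this assay, chloro in place of methyl gives a 2.4-fold higher number from compound 3 to compound 4 (0.37 log units; beyond the scatter), and chloro in place of methoxy gives a 9.9-fold higher number from compound 2 to compound 4 (1.00 log units; beyond the scatter), leaving compound 4 the weakest of the four and widening the spread among the para substituents. Replacing furan-2-yl with 4-chlorophenyl gives a 5.0-fold higher number from compound 1 to compound 4 (0.69 log units; beyond the scatter), so that aryl group falls short of the furan, as 4-methylphenyl does, while 4-methoxyphenyl stays within the scatter of it. No measurement on hand accounts for this order. Still open, going by these compounds, is how an amine or a carboxylic acid would behave at this ring position.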